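Difluorophenyl Replaces Cyanophenyl on the Cyclopropane Ring

The source may report more compounds than this note shows. Statements on the series, on what has been measured and on what is new or still open speak of the compounds shown alone.

Compound 1 `CC[C@H](C)[C@H](N)CN(C(=O)[C@@H]1C[C@H]1c1cccc(F)c1)c1ccc(-c2ccccc2)cc1` gives 560 nM in a functional assay for agonist activity at G protein-coupled receptor 88 (Homo sapiens), read by HTRF and cAMP accumulation; on this read-out higher numbers stand for an effect only at larger amounts of compound and lower numbers for an effect already at smaller amounts. Compound 2 `CC[C@H](C)[C@H](N)CN(C(=O)[C@@H]1C[C@H]1c1ccc(C#N)cc1)c1ccc(-c2ccccc2)cc1` differs from it in carrying 4-cyanophenyl in place of 3-fluorophenyl on a saturated ring carbon. In this assay compound 2 reaches only a limit of the measurement, > 25000 nM. That change produced an at least 44-fold higher number from compound 1 to compound 2 (1.64 log units; beyond the scatter), and the size of this step is itself bounded by the limit of > 25000 nM in this assay, at which 1 of the 2 values shown sits.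

Compound 3 `CC[C@H](C)[C@H](N)CN(C(=O)[C@@H]1C[C@H]1c1ccc(F)cc1F)c1ccc(-c2ccccc2)cc1` now carries 2,4-difluorophenyl where compound 2 carries 4-cyanophenyl (2,4-difluorophenyl in place of 4-cyanophenyl on a saturated ring carbon). Among the measured compounds shown here, no measured step covers this exact change. The only step shown, from compound 1 to compound 2, says that the nitrile-bearing ring sits far beyond the fluorinated ring; returning to a fluorinated ring, though with two fluorines rather than one, is therefore expected to bring a large step back toward the number of compound 1, an at least 16-fold lower number from compound 2 to compound 3 (1.22 log units; beyond the scatter). Compound 3 is estimated at 1500 nM, within 300 nM to 8000 nM.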

Compound 3, half-maximal effective concentration: 1300 nM
For compound 3 the middle estimate is 1.2-fold (0.06 log units) above the measured one; the measured number falls inside the stated range.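

In this assay, 2,4-difluorophenyl on this cyclopropane carbon restores a measurable response, with an at least 19-fold lower number from compound 2 to compound 3 (1.28 log units; beyond the scatter), and the size of that step is bounded by a limit: the limit of > 25000 nM in this assay, at which 1 of the 3 values shown sits. Exchanging 3-fluorophenyl for 2,4-difluorophenyl brings a 2.3-fold higher number from compound 1 to compound 3 (0.37 log units; beyond the scatter), so the two fluorinated rings lie fairly close together, while 4-cyanophenyl stands apart from both. The loss seen with 4-cyanophenyl therefore does not extend to every phenyl ring with a substituent named at 4, since 2,4-difluorophenyl carries one and still gives a measurable number.

On these data alone, what 4-fluorophenyl or 3-cyanophenyl would give on the same carbon stays open, and with it whether the loss follows the nitrile itself or its place on the ring. Also open, as far as these compounds go, is how a methoxy group, a methyl group or an unsubstituted phenyl ring would fare here.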